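Acylsulfonamide to acid on an EP4 ligand

The source may hold more compounds than are shown below. What is called first, only, known or untested is meant among the compounds shown, and "the series" means these compounds.

Measured so far:
compound 1, `COc1ccccc1-c1ccc(OCc2cc(C(=O)O)oc2C)cc1`, 1600 nM
compound 2, `COc1ccc(-c2ccc(OCc3cc(C(=O)NS(=O)(=O)c4c(C)noc4C)oc3C)cc2)nc1`, 13 nM

Going by the values given here, in an assay on cells for displacement of a labelled ligand from prostaglandin E2 receptor EP4 subtype (Homo sapiens), read by scintillation counting (on this read-out lower numbers stand for stronger inhibition and higher numbers for weaker inhibition), compound 2 gives the lower of the two numbers seen here; the only neighbour is compound 1, whose number is higher by a gap beyond the scatter. Compound 1 and compound 2 differ in more than one place, so their two values alone cannot be tied to a single change.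

The next compound, compound 3, `COc1ccc(-c2ccc(OCc3cc(C(=O)O)oc3C)cc2)nc1`, keeps everything in compound 2 except one group: hydroxy in place of ((3,5-dimethyl-1,2-oxazol-4-yl)sulfonyl)amino on a carbonyl carbon. Among the compounds with values here, no step of exactly this kind has been measured. The closest reference is compound 1, which also carries the acid on the same end of the molecule and sits far above compound 2 in this assay. Compound 3 is therefore expected to show a clearly weaker value than compound 2, with an estimated step of a 54-fold higher number from compound 2 to compound 3 (1.73 log units; beyond the scatter). The estimate for compound 3 is 700 nM, ranging from 150 nM to 3000 nM.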

Compound 3, inhibition constant: 1300 nM
Beside the measured number, compound 3's estimate is 1.9-fold (0.27 log units) below it, within the range that was stated.
By their numbers in this assay, from the lowest: compound 2; then compounds 3 and 1 (each within the scatter of the next).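

Compound 2 and compound 3 differ in one place only, so the large change in this assay can now be tied to a single group: hydroxy in place of ((3,5-dimethyl-1,2-oxazol-4-yl)sulfonyl)amino on the carbonyl carbon gives a 100-fold higher number from compound 2 to compound 3 (2.00 log units; beyond the scatter) on an otherwise unchanged molecule. Among the acids, 5-methoxypyridin-2-yl in place of 2-methoxyphenyl gives a 1.2-fold lower number from compound 1 to compound 3 (0.09 log units; within the scatter) and so makes no difference that can be told from the scatter. Nothing available here gives a measured reason for the size of either step.

Going by these compounds, it remains open whether 2-methoxyphenyl would be equally interchangeable with 5-methoxypyridin-2-yl when the ((3,5-dimethyl-1,2-oxazol-4-yl)sulfonyl)amino group is present. On these data alone, it is also open whether that group's five-membered ring matters, or whether a smaller methylsulfonylamino group on the same carbonyl carbon would give a similarly low number.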